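This account rests on a few compounds, and the source may have more. Where it says the series, first, only, none or still open, it means among the compounds named here.

Measured so far:
compound 1 `CN(C)CCCOc1c(-c2ccc(O)c(O)c2)oc2ccccc2c1=O` — 1000 nM
compound 2 `C[N+](C)(C)CCCOc1c(-c2ccc(O)c(O)c2)oc2ccccc2c1=O` — 1200 nM

Among the measured compounds shown here, in a functional assay for inhibition, with Rattus norvegicus as the target, using microsomes (on this read-out lower numbers stand for stronger inhibition and higher numbers for weaker inhibition), compound 2 gives the highest of the two numbers, but the only measured step, a 1.2-fold higher number from compound 1 to compound 2 (0.08 log units; within the scatter), leaves the pair within the scatter. Compound 3 `O=c1c(OC[C@H]2O[C@H](O)[C@H](O)[C@@H](O)[C@@H]2O)c(-c2ccc(O)c(O)c2)oc2ccccc12` is unmeasured; it differs from compound 2 by a group of 10 heavy atoms (5 carbon, 5 oxygen; one six-membered non-aromatic ring with 1 hetero atom) in place of a group of 6 heavy atoms (5 carbon, 1 nitrogen; no ring), on a saturated chain carbon bound to an oxygen on an aromatic ring. For the measured compounds named here, the single step in hand concerns a different change, and no measured compound carries the entering group, so it bears only weakly on this one. The expectation for compound 3 in this assay is therefore loosely held: a 2.1-fold higher number from compound 2 to compound 3 (0.32 log units; beyond the scatter). Compound 3 is estimated at 2500 nM, with a range from 600 nM to 10000 nM.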

Compound 3, half-maximal inhibitory concentration: 2800 nM
Beside the measured number, compound 3's estimate is 1.1-fold (0.05 log units) below it; the measured number falls inside the stated range.
By their numbers in this assay, from the lowest: compounds 1 and 2 (each within the scatter of the next); then compound 3.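

In this assay, putting 3,4,5,6-tetrahydroxyoxan-2-yl on the saturated chain carbon bound to an oxygen on an aromatic ring gives a 2.3-fold higher number from compound 2 to compound 3 (0.37 log units; beyond the scatter) and a 2.8-fold higher number from compound 1 to compound 3 (0.45 log units; beyond the scatter), both modest. Among the compounds shown here, these are the first steps beyond the scatter, and they show that this place accepts a ring with no net charge in place of either amine chain at only a modest cost. Nothing measured here accounts for the shift.

Going by these compounds, whether the step follows the ring itself or its hydroxyl groups stays open. Also open, on these data alone, is how a carboxylic acid or a longer amine chain would read at this place.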